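Compound 4 and the flat methoxy steps

A few compounds are considered here, and "the series" means these few. Any claim that something is new, unique, unknown or untested is made for them only; others in the source may bear on it.

In a physicochemical assay for pharmacokinetics, read by fluorescence and HPLC, with a stated time of 24 h (a higher number here means that the compound lasts longer, a lower number that the compound disappears faster), compound 1 `CC(C)(C)C1=C(C(=O)O)N2C(=O)/C(=C/c3ccccc3)C2O1` reads 0.21 h and compound 2 `COc1ccccc1/C=C1/C(=O)N2C(C(=O)O)=C(C(C)(C)C)OC12` reads 0.2 h while compound 3 `COc1cccc(/C=C2/C(=O)N3C(C(=O)O)=C(C(C)(C)C)OC23)c1` reads 0.21 h and so stands level with compound 1, with compound 2 within the scatter of both. Compound 4 `COc1ccc(/C=C2/C(=O)N3C(C(=O)O)=C(C(C)(C)C)OC23)cc1` differs from compound 3 in one place: 4-methoxyphenyl in place of 3-methoxyphenyl on a double-bonded chain carbon bound to a double-bonded ring carbon with 4-methoxyphenyl in place of 3-methoxyphenyl on a double-bonded chain carbon bound to a double-bonded ring carbon. Methoxy in place of hydrogen on an aromatic carbon gave a 1.1-fold lower number from compound 1 to compound 2 (0.02 log units; within the scatter) and also no change at the digits printed from compound 1 to compound 3 (within the scatter) in the two steps of that kind, while 3-methoxyphenyl in place of 2-methoxyphenyl gave a 1.1-fold higher number from compound 2 to compound 3 (0.02 log units; within the scatter) as the closest parallel. Within the data shown here, no compound carrying 4-methoxyphenyl has a measured value, so the expectation rests on these three steps alone. All three lie within the scatter, so the expected size is no change at the digits printed from compound 3 to compound 4 (within the scatter) with neither direction favoured. In this assay the estimate for compound 4 is 0.21 h with a range from 0.14 h to 0.33 h around it.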

Compound 4, half-life: 0.2 h
For compound 4 the middle estimate is 1.1-fold (0.02 log units) above the measured one; the measured number falls inside the stated range.
By their numbers in this assay, from the lowest: compounds 2, 4, 1 and 3 (each within the scatter of the next).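

In this assay the change to 4-methoxyphenyl gives a 1.1-fold lower number from compound 3 to compound 4 (0.02 log units; within the scatter) and no change at the digits printed from compound 2 to compound 4 (within the scatter), so the methoxy group on the phenyl ring attached to the double-bonded chain carbon now appears in all three arrangements, and none separates from the others. Set against the unsubstituted phenyl group, the same group gives a 1.1-fold lower number from compound 1 to compound 4 (0.02 log units; within the scatter), which makes this the third methoxy in place of hydrogen step to stay within the scatter, with no exception among compounds 1 to 4. Nothing in the material shown bears on why the half-life stays so flat across these changes.

The compounds shown leave open whether a group other than methoxy on this phenyl ring, such as an amine, a nitrile or a longer ether chain, would move the half-life beyond the scatter. They also leave open whether any change to the shared core would do so.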